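Replacing 3-(methoxycarbonyl)phenyl with benzyl: a stability estimate

A few compounds are considered here, and "the series" means these few. Any claim that something is new, unique, unknown or untested is made for them only; others in the source may bear on it.

In an ADME assay on S9 fraction from liver (Rattus norvegicus) for metabolic stability, read by LC-MS, using NADPH, with a stated time of 30 min (on this read-out lower numbers stand for a less stable compound and higher numbers for a more stable compound), compound 1 `CCCCCCCCc1ccc(OCC(=O)Cn2ncnn2)cc1` gives < 5%, which is a limit of the assay and not a number.

Compound 2 `CCCCCCCCc1ccc(OCC(=O)Cn2cnnn2)cc1` gives 22% and compound 3 `CCCCCCCCc1ccc(OCC(=O)Cn2nnc(-c3cccc(C(=O)OC)c3)n2)cc1` gives 19%, two values within the scatter of each other. Compound 4 `CCCCCCCCc1ccc(OCC(=O)Cn2nnc(Cc3ccccc3)n2)cc1` has benzyl in place of 3-(methoxycarbonyl)phenyl on an aromatic carbon.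

Two measured steps exist. The a number at least 17 percentage points higher from compound 1 to compound 2 (beyond the scatter) belongs to a different change, 1H-tetrazol-1-yl in place of 2H-tetrazol-2-yl. The a number at least 14 percentage points higher from compound 1 to compound 3 (beyond the scatter) is closer, since it comes with 3-(methoxycarbonyl)phenyl in place of hydrogen on the same carbon. As far as these compounds go, both start from a limit (the limit of < 5% in this assay, at which 1 of the 3 values shown sits), so their true sizes remain open. Going by the values given here, no measured step exchanges one such group for another, so no clear direction can be drawn for this assay.

The expected change is a number 1 percentage points lower from compound 3 to compound 4 (within the scatter), which would stay within the scatter. For compound 4, the estimated value is 18%, with an expected range from 6% to 35%.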

Compound 4, percent of the compound remaining: < 5%
Compound 4: no number, only a limit; the forecaster's own chance of this, stated with the estimate: 15%; middle value at least 13 percentage points away from the limit.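

Compound 4 gives < 5%, which is a limit of the assay and not a number. Even so, the exchange on this aromatic carbon of the five-membered ring can be read in this assay as a number at least 14 percentage points lower from compound 3 to compound 4 (beyond the scatter), so 3-(methoxycarbonyl)phenyl and benzyl are not interchangeable here, although each brings one six-membered aromatic ring of carbon only. The step from compound 1 to compound 4 cannot be read, and the lower end of the read-out now holds more of the series: the limit of < 5% in this assay, at which 2 of the 4 values shown sit.

Benzyl and 3-(methoxycarbonyl)phenyl differ both in the methoxycarbonyl group and in the extra carbon that benzyl places before its ring, and the compounds shown do not separate these two differences. As far as these compounds go, how a plain phenyl, or a phenyl carrying a carboxylic acid, would fare on this carbon remains open.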